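The compounds below may be only part of what the source reports. "The series", "measured", "known", "first", "only" and "open" are said of these compounds alone.

Compound 1 `CS(=O)(=O)c1ccc(-c2nc3ccccn3c2Sc2ccccc2)cc1` sits at a limit in an ADME assay on NIH3T3 cells (Mus musculus) for inhibition, read by MTT assay, with a stated time of 48 h (on this read-out higher numbers stand for weaker inhibition and lower numbers for stronger inhibition), where compound 1 gives > 100000 nM. The other measured analogue, compound 2 `CSc1ccc(-c2nc3ccccn3c2Sc2ccccc2)cc1`, also sits at a limit; in this assay compound 2 gives > 100000 nM. The step that the two limits leave unreadable from compound 1 to compound 2 thus cannot be read, and both values rest at the limit of > 100000 nM in this assay, at which 2 of the 2 values shown sit. Compound 3 `CS(=O)(=O)c1ccc(-c2nc3ccccn3c2Sc2cccc3ccccc23)cc1` differs from compound 1 by naphthalen-1-yl in place of phenyl on a sulfur. For the measured compounds named here, no measured step covers this change, so no size or direction beyond the scatter can be drawn from the measured pairs. Compound 3 is therefore expected to stay near the limit as well, with an estimated 150000 nM (range 50000 nM to 500000 nM), which means an expected step that the limit leaves unreadable from compound 1 to compound 3.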

Compound 3, half-maximal inhibitory concentration: 86400 nM
Estimate against measurement, compound 3: 1.7-fold (0.24 log units) above, within the range that was stated.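

In this assay, for the compounds shown here, compound 3 is the first compound of the series to give a number rather than a limit, so naphthalen-1-yl on this sulfur is the first change here with a readable value. Compound 1 stays a limit, so the result is only a floor: an at least 1.1-fold lower number from compound 1 to compound 3 (0.06 log units; that floor lies within the scatter) is all that can be said of this step, and it does not establish a real gain in inhibition.

From the compounds shown here alone, what an amine or a longer alkyl chain on this sulfur would give in place of phenyl stays open. Also open, going by these compounds, is whether naphthalen-1-yl gives a readable number with methylsulfanyl in place of methylsulfonyl.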